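Imidazole Amide in Place of Fluorophenyl: Expected to Stay Non-Toxic

A few compounds are considered here, and "the series" means these few. Any claim that something is new, unique, unknown or untested is made for them only; others in the source may bear on it.

Compound 1, `COc1ccccc1-c1cnc(NC(=O)c2ccc(F)cc2)n1C`: in a toxicity assay on THP-1 cells (Homo sapiens) for inhibition (on this read-out lower numbers stand for higher toxicity in this test and higher numbers for lower toxicity in this test), compound 1 gives > 100000 nM, which is a limit of the assay.
Compound 2, `Cn1c(-c2ccc(C#N)cc2)cnc1NC(=O)c1ccc(F)cc1`: in this assay compound 2 gives > 50000 nM, which is a limit of the assay.
Compound 3, `Cn1c(-c2cccc(C#N)c2)cnc1NC(=O)c1ccc(F)cc1`: in this assay compound 3 gives > 100000 nM, which is a limit of the assay.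

Compound 3 therefore stands at the limit of > 100000 nM in this assay, at which 2 of the 3 values shown sit, and no number is known for it. All three measured steps, a step that the two limits leave unreadable from compound 1 to compound 2, a step that the two limits leave unreadable from compound 1 to compound 3 and a step that the two limits leave unreadable from compound 2 to compound 3, vary the group on the aromatic carbon of the shared core, and each is unreadable: both ends are limits. Compound 4, `Cn1c(-c2cccc(C#N)c2)cnc1NC(=O)c1ncc[nH]1`, differs from compound 3 at the other end of the molecule.

1H-imidazol-2-yl in place of 4-fluorophenyl on a carbonyl carbon

Going by the values given here, none of the measured steps touches the carbonyl carbon, so none bears directly on this change; together they show only that every measured value sits at the limit of > 100000 nM in this assay, at which 2 of the 3 values shown sit, or (the limit of > 50000 nM in this assay, at which 1 of the 3 values shown sits). With no readable step and no measured number anywhere, the expected step of a number no higher from compound 3 to compound 4 (the limit leaves the size open) is no step beyond the scatter, and compound 4 is expected to come back as a limit once more. Compound 4 is estimated at 100000 nM, within 40000 nM to 250000 nM.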

Compound 4, half-maximal cytotoxic concentration: > 50000 nM
Compound 4: no number, only a limit (the forecaster's own chance of this, stated with the estimate: 85%); the middle value is on the limit's open side.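

In this assay compound 4 gives > 50000 nM, which is a limit of the assay. Compound 3 also stands at a limit, so no step can be read between compound 3 and compound 4. The compounds shown leave open whether 1H-imidazol-2-yl in place of 4-fluorophenyl on a carbonyl carbon shifts toxicity in this test at all.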